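Aryloxy variation on the diamino core: dichloro to fluoro

A few compounds are considered here, and "the series" means these few. Any claim that something is new, unique, unknown or untested is made for them only; others in the source may bear on it.

Compound 1 `Nc1cc(N)c2nc(-c3ccccc3)c(Oc3ccc(Cl)c(Cl)c3)nc2c1` carries a 3,4-dichlorophenoxy group on the shared core. In a functional assay on OVCAR-5 cells (Homo sapiens) for inhibition, read by sulforhodamine B assay, with a stated time of 48 h (on this read-out higher numbers stand for weaker inhibition of growth and lower numbers for stronger inhibition of growth), compound 1 gives 25100 nM, the lower of the two numbers in hand. Compound 3 `CCOC(=O)[C@H](CCC(=O)O)NC(=O)c1ccc(Sc2nc3cc(N)cc(N)c3nc2-c2ccccc2)cc1`, which bears a thioether-linked benzamide of a glutamate ester, gives in this assay 60300 nM; the gap between compound 1 and compound 3 lies beyond the usual scatter of repeated runs. Compound 2 `CCOC(=O)[C@H](CCC(=O)O)NC(=O)c1ccc(CNc2nc3cc(N)cc(N)c3nc2-c2ccccc2)cc1` returns only a limit in this assay, < 100000 nM, so it contributes no number to the comparison (the limit of < 100000 nM in this assay, at which 1 of the 3 values shown sits).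

Compound 4 `Nc1cc(N)c2nc(-c3ccccc3)c(Oc3ccc(F)cc3)nc2c1` has not yet been measured. It differs from compound 1 in one place: 4-fluorophenyl in place of 3,4-dichlorophenyl on an oxygen on an aromatic ring. For the measured compounds named here, no measured pair in this set isolates that change, so the direction of the step rests on expectation only. With one fluorine in place of two chlorines on the aryloxy group, a modest weakening of growth inhibition is expected rather than a gain, but the step from compound 1 to compound 4 is estimated as a 1.8-fold higher number from compound 1 to compound 4 (0.25 log units; within the scatter), which may still fall within the scatter. The expected value for compound 4 in this assay is 45000 nM, with a likely range from 15000 nM to 120000 nM; a result near the upper end could be reported only as a limit.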

Compound 4, concentration for 50% growth inhibition: 20400 nM
Estimate against measurement, compound 4: 2.2-fold (0.34 log units) above, and the stated range covers the measured number.
By their numbers in this assay, from the lowest: compounds 4 and 1 (each within the scatter of the next); then compound 3.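

For the compounds shown here, the exchange of 3,4-dichlorophenoxy for 4-fluorophenoxy is the first change that can be read in one place, and in this assay it comes to a 1.2-fold lower number from compound 1 to compound 4 (0.09 log units; within the scatter). At this position, on an oxygen on an aromatic ring, the two chlorines of the 3,4-dichlorophenyl group and the single fluorine of the 4-fluorophenyl group are therefore not told apart by this read-out, so neither aryl group can be ranked over the other, and the pair gives no sign of a direction for halogen change on this ring. No measured property in hand bears on this step, so the result stays a plain observation without an explanation.

From the compounds shown here alone, whether growth inhibition responds to this position at all remains open, since both aryl groups compared here are halogen-bearing phenyl rings, and a phenyl ring carrying a carboxylic acid or an amine, or a longer alkyl chain on the oxygen, would probe a far wider change. The role of the oxygen link itself also remains open, as the compounds shown offer no pair that changes that atom alone.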